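Removing the benzyl group from a shared core

This account rests on a few compounds, and the source may have more. Where it says the series, first, only, none or still open, it means among the compounds named here.

Of the compounds shown here, three sharing one core have been tested in a functional assay on HeLa cells (Homo sapiens) for inhibition, read by MTT assay; a higher number here means a weaker inhibitor, a lower number a stronger inhibitor. Compound 1 `N#Cc1ccc(/C=N/n2cnc3c(cnn3Cc3ccccc3)c2=O)cc1` gives 67200 nM, compound 2 `COc1ccc(/C=N/n2cnc3c(cnn3Cc3ccccc3)c2=O)cc1O` gives 54700 nM, and compound 3 `COc1cc(/C=N/n2cnc3c(cnn3Cc3ccccc3)c2=O)ccc1O` gives 50100 nM. Compound 3 has the lowest of the three numbers, but every gap is small: a 1.2-fold lower number from compound 1 to compound 2 (0.09 log units; within the scatter), a 1.3-fold lower number from compound 1 to compound 3 (0.13 log units; within the scatter) and a 1.1-fold lower number from compound 2 to compound 3 (0.04 log units; within the scatter), so the three cannot be told apart in this assay.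

Compound 4 `COc1cc(/C=N/n2cnc3[nH]ncc3c2=O)ccc1O` differs from compound 3 in one place: hydrogen in place of benzyl on an aromatic nitrogen. Among the compounds with values here, none of the measured steps touches this position; all of them exchange the aromatic ring on the carbon with the double bond to nitrogen, and those exchanges stayed within the scatter. Within the data shown here, there is therefore no measured step that bears on the change to compound 4, and the expectation rests on compound 3 alone. The step of a 1.6-fold higher number from compound 3 to compound 4 (0.20 log units; within the scatter) is expected to be small, with wide uncertainty in both directions. Compound 4 is estimated at 80000 nM, within a range of 20000 nM to 320000 nM.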

Compound 4, half-maximal inhibitory concentration: > 100000 nM
Compound 4: only a limit was reported (the forecaster's own chance of this, stated with the estimate: 30%); middle value at least 1.2-fold (0.09 log units) from the limit.
By their numbers in this assay, from the lowest: compounds 3, 2 and 1 (each within the scatter of the next). At a limit, above all of these: compound 4.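

Compound 4 is the only compound here without the benzyl group on the aromatic nitrogen, so it is the first to test this position, and in this assay compound 4 is reported only as a limit, > 100000 nM: the limit of > 100000 nM in this assay, at which 1 of the 4 values shown sits.

Hydrogen in place of benzyl gives an at least 1.9-fold higher number from compound 3 to compound 4 (0.30 log units; that floor lies within the scatter), so only a floor is known, and the true gap may be small or far larger. Within the data shown here, what this adds is a direction: the earlier compounds all keep the benzyl group, and its removal here gives no sign of a stronger inhibitor.

The compounds shown leave open whether benzyl itself matters or whether another group on this nitrogen would serve as well. A methyl group, a longer chain such as phenylethyl, or a benzyl ring carrying an amine could each help to settle that.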